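The source may hold more compounds than are shown below. What is called first, only, known or untested is meant among the compounds shown, and "the series" means these compounds.

Measured so far:
compound 1, `Cc1nc2sc(-n3ccnc3)nc2c(=O)[nH]1`: 1%
compound 2, `CCOc1nc(C)nc2sc(Nc3ccccc3)nc12`: 2%

Both values come from an assay on CHO cells for displacement of a labelled ligand from adenosine receptor A1 (Homo sapiens), read by scintillation counting, with a stated time of 120 min, tested at 1 uM; a lower number here means less inhibition, a higher number more inhibition at the concentration tested (going by the name of the read-out). Of the two numbers, compound 2 is the higher, but its difference from compound 1 is within the usual scatter, so the two count as alike. Compound 3, `CCOc1nc(C)nc2sc(Nc3cccc(OC)c3)nc12`, has not been measured. It differs from compound 2 by methoxy in place of hydrogen on an aromatic carbon. Among the measured compounds shown here, no step between measured compounds is available to guide this change. Compound 2 gives only 2% in this assay, leaving little room to fall. The step of a number 2 percentage points higher from compound 2 to compound 3 (within the scatter) is expected to be small, upward if anything, and within the scatter. Compound 3 is therefore estimated at 4%, ranging from -5% to 15%.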

Compound 3, a percentage reported as inhibition, at one concentration (the size of the read-out at that concentration, not a potency): 3%
Compound 3: the middle estimate sits 1 percentage points above what was measured; the measured number falls inside the stated range.
By their numbers in this assay, from the lowest: compounds 1, 2 and 3 (each within the scatter of the next).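

Putting methoxy in place of hydrogen on an aromatic carbon, meta to a large group, gives in this assay a number 1 percentage points higher from compound 2 to compound 3 (within the scatter), so the two compounds count as alike. Among the compounds shown here, this is the first single-place change that can be read, and compound 3 still gives only 3% at the concentration tested. Nothing at hand bears on why the number stays so low.

Still open, on these data alone, is whether an amine or a carboxylic acid at this same place would give a different number. A longer chain in place of the ethoxy group is equally untested among the compounds shown.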